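Cyclopentyl for Methyl in a Metabotropic Glutamate Receptor 3 Modulator

A few compounds are considered here, and "the series" means these few. Any claim that something is new, unique, unknown or untested is made for them only; others in the source may bear on it.

Among the measured compounds shown here, compound 2 `CCC(=O)c1ccc(OCCCCOc2cc(C(=O)O)ccc2OC)c(C)c1O` is the only compound with a number in an assay on HEK293 cells for positive allosteric modulation of metabotropic glutamate receptor 3 (Rattus norvegicus), read by thallium flux, with a stated time of 2.5 min; on this read-out higher numbers stand for an effect only at larger amounts of compound and lower numbers for an effect already at smaller amounts: compound 2 gives 6360 nM. Compound 1 `COC(=O)c1ccc(OCCCCOc2ccc(C(=O)CC3CCCC3)c(O)c2C)cc1` is reported as "not determined" (no result reported) in this assay, so compound 2 stands alone. Compound 3 `COc1ccc(C(=O)O)cc1OCCCCOc1ccc(C(=O)CC2CCCC2)c(O)c1C` differs from compound 2 by cyclopentyl in place of methyl on a saturated chain carbon bound to a carbonyl carbon. For the measured compounds named here, with no measured pair showing this change, the step from compound 2 to compound 3 is expected to be modest, a 2.1-fold lower number from compound 2 to compound 3 (0.33 log units; beyond the scatter), toward an effect at smaller amounts. Compound 3 is therefore estimated at 3000 nM, with a range from 1000 nM to 15000 nM.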

Compound 3, half-maximal effective concentration: 1020 nM
Compound 3: middle estimate off by 2.9-fold (0.47 log units), on the high side; the range from low to high includes it.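

Cyclopentyl in place of methyl on a saturated chain carbon bound to a carbonyl carbon gives a 6.2-fold lower number from compound 2 to compound 3 (0.79 log units; beyond the scatter) in this assay and is the first measured change at this position. The position therefore accepts this five-membered carbon ring, and the effect appears at smaller amounts than with methyl. Nothing available explains this step. The compounds shown leave open whether the step depends on the ring itself or would also follow from a longer chain such as butyl. Going by these compounds, how a phenyl ring would read at this position also remains open.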